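A few compounds are considered here, and "the series" means these few. Any claim that something is new, unique, unknown or untested is made for them only; others in the source may bear on it.

The measured compounds so far:
Compound 1, `C#Cc1cccc(NC(=O)CCc2cccc3c2B(O)OC3)c1`: 980 nM
Compound 2, `Cc1cc(C)c(NC(=O)CCc2cccc3c2B(O)OC3)c(C)c1`: 19000 nM

In a functional assay on SK-OV-3 cells (Homo sapiens) for antiproliferative activity, read by MTT assay, with a stated time of 72 h (on this read-out higher numbers stand for weaker inhibition and lower numbers for stronger inhibition), compound 1 gives 980 nM, the lower of the two numbers recorded. Compound 2 gives 19000 nM in this assay, a higher number that lies beyond the usual scatter, so compound 1 stands as the stronger inhibitor of the pair. Compound 3, `CC(=O)c1cccc(-c2cccc(NC(=O)CCc3cccc4c3B(O)OC4)c2)c1`, has not yet been tested. It differs from compound 1 in one place: 3-acetylphenyl in place of ethynyl on an aromatic carbon. The group that enters brings one six-membered aromatic ring of carbon only and one hydrogen-bond acceptor, where the ethynyl group brought neither. Going by the values given here, no measured pair isolates this change, and compound 2 shows only that another substitution pattern weakens inhibition. The account therefore expects a small step from compound 1 to compound 3, a 1.6-fold higher number from compound 1 to compound 3 (0.21 log units; within the scatter), toward a weaker result, possibly within the scatter. Compound 3 is estimated at 1600 nM, with a range from 400 nM to 6500 nM.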

Compound 3, half-maximal inhibitory concentration: 68 nM
Beside the measured number, compound 3's estimate is 24-fold (1.37 log units) above it; measured number below the stated range.
By their numbers in this assay, from the lowest: compound 3; then compound 1; then compound 2.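

In this assay, the step at this position is a 14-fold lower number from compound 1 to compound 3 (1.16 log units; beyond the scatter), with 3-acetylphenyl in place of ethynyl on an aromatic carbon of a six-membered aromatic ring of carbon only. This shows that the position tolerates a much larger group than ethynyl, one that brings a further aromatic ring and a hydrogen-bond acceptor, and that this change strengthens inhibition in these cells rather than weakening it. Nothing available here bears on the reason for the gain.

The compounds shown leave open whether the gain comes from the added aromatic ring alone or needs the acetyl group on it, a question that a plain phenyl group would address. They also leave open whether an amine or a carboxylic acid in place of that acetyl group would hold the gain.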